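A few compounds are considered here, and "the series" means these few. Any claim that something is new, unique, unknown or untested is made for them only; others in the source may bear on it.

For the measured compounds named here, compound 1, with the structure `COc1ccccc1Oc1cncc(C2=CC3CNCC(C2)C3)c1`, is one of two compounds measured here. In an in vitro assay on SH-EP1 cells for displacement of a labelled ligand from Neuronal acetylcholine receptor; alpha4/beta2 (Homo sapiens) (on this read-out lower numbers stand for stronger inhibition and higher numbers for weaker inhibition), compound 1 gives 1 nM. The other measured compound is compound 2, with the structure `C1=C(c2cccnc2)CC2CNCC1C2`, which in this assay gives 0.2 nM. Compound 1 therefore stands at the higher of the two numbers, and the gap to compound 2 is wider than the usual scatter of repeated measurements.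

The new compound is compound 3, with the structure `Clc1ccc(Oc2cncc(C3=CC4CNCC(C3)C4)c2)cc1`. Compared with compound 1 it carries 4-chlorophenyl in place of 2-methoxyphenyl on an oxygen on an aromatic ring. Going by the values given here, no measured pair shows such a change, so there is no precedent to lean on; the expectation rests on compound 1 alone. The step of a 1.5-fold higher number from compound 1 to compound 3 (0.18 log units; within the scatter) is expected to be modest, if any beyond the scatter. Compound 3 is therefore estimated at 1.5 nM, with a range from 0.4 nM to 6 nM.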

Compound 3, inhibition constant: 1.9 nM
Estimate against measurement, compound 3: 1.3-fold (0.10 log units) below; the range from low to high includes it.
By their numbers in this assay, from the lowest: compound 2; then compounds 1 and 3 (each within the scatter of the next).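

In this assay, placing 4-chlorophenyl instead of 2-methoxyphenyl on the oxygen gives a 1.9-fold higher number from compound 1 to compound 3 (0.28 log units; within the scatter), so compound 1 and compound 3 cannot be told apart. The aromatic group on this oxygen can therefore be exchanged without a change beyond the scatter, even though the group that leaves has a hydrogen-bond acceptor and the one that enters has none. Nothing measured here explains why this exchange is tolerated.

Since the methoxy group leaves and the chlorine enters in the same step, their separate contributions cannot be read. As far as these compounds go, it also remains open whether this tolerance extends to an amine or a carboxylic acid on the phenyl ring, or to a longer carbon chain in place of the ring.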